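Methyl in Place of Chloro: Expected Lipophilicity of Compound 3

The source may report more compounds than this note shows. Statements on the series, on what has been measured and on what is new or still open speak of the compounds shown alone.

Compound 1 `Cn1c(COc2cccc(C(=O)O)c2)nc2ccc(Oc3ccccn3)cc21` gives 0.4 in a physicochemical assay for lipophilicity, read by LC-MS, in phosphate buffer, measured as octanol-water partition, with a stated time of 30 min, at pH 7.4, tested at 200 mM; on this read-out lower numbers stand for lower lipophilicity and higher numbers for higher lipophilicity. Compound 2 `Cn1c(COc2cccc(C(=O)O)c2)nc2ccc(Oc3ncccc3Cl)cc21` gives 1.1 in this assay.

Of the two numbers, the higher belongs to compound 2. Within the data shown here, the one measured step is a number 0.70 log units higher from compound 1 to compound 2 (beyond the scatter), a chloro entering for hydrogen. Compound 3 `Cc1cccnc1Oc1ccc2nc(COc3cccc(C(=O)O)c3)n(C)c2c1` differs from compound 2 by methyl in place of chloro on an aromatic carbon. Among the measured compounds shown here, that measured step bears on this change only indirectly, since no measured pair sets methyl against chloro. The expected step of a number 0.20 log units lower from compound 2 to compound 3 (within the scatter) is therefore small and within the scatter. The estimate for compound 3 is 0.9, ranging from 0.5 to 1.3.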

Compound 3, distribution coefficient: 0.9
Compound 3: middle estimate and measured number agree at the digits printed, within the range that was stated.
By their numbers in this assay, from the lowest: compound 1; then compounds 3 and 2 (each within the scatter of the next).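

In this assay, this position does not separate methyl from chloro (a number 0.20 log units lower from compound 2 to compound 3 (within the scatter)). Methyl in place of hydrogen still gives a step beyond the scatter (a number 0.50 log units higher from compound 1 to compound 3 (beyond the scatter)), so at this position such a step is no longer seen with chloro alone. No available measurement explains either step.

Going by these compounds, whether fluoro, methoxy or an amine on this aromatic carbon would give numbers close to those of chloro and methyl stays open. So does whether methyl and chloro stay this close elsewhere on the ring.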